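This account rests on a few compounds, and the source may have more. Where it says the series, first, only, none or still open, it means among the compounds named here.

Of the compounds shown here, three have so far been measured in an assay for inhibition of serine/threonine-protein kinase PLK2 (Homo sapiens), read by FRET and Z'-LYTE, with a stated time of 1 h; on this read-out higher numbers stand for weaker inhibition and lower numbers for stronger inhibition. Compound 1 `CC[C@@H]1C(=O)N(C)c2cnc(-n3ccc4cc(C(N)=O)ccc43)nc2N1C1CCCC1` gives 28.5 nM in this assay. Compound 3 `CC[C@@H]1C(=O)N(C)c2cnc(Nc3ccc(S(N)(=O)=O)cc3)nc2N1C1CCCC1` gives 10.2 nM in this assay, a number lower than that of compound 1 by more than the usual scatter, while compound 2 `CCC1C(=O)N(C)c2cnc(-n3ccc4cc(F)ccc43)nc2N1c1ccn(C)n1` gives 1500 nM in this assay, far higher than compound 1. Compound 1 therefore stands second highest of the three numbers, clearly separated from both of the others.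

Compound 4 `CC[C@@H]1C(=O)N(C)c2cnc(-n3ccc4cc(C(=O)NCC(C)C)ccc43)nc2N1C1CCCC1` has not yet been measured. It differs from compound 1 in one place: isobutyl in place of hydrogen on an amide-type nitrogen, so that the carbamoyl group becomes an isobutylcarbamoyl group. Within the data shown here, no measured pair in this set makes a comparable change, so there is nothing here to set the size or direction of the step. In this assay a step no larger than the usual scatter is expected, in either direction, which amounts to a 1.4-fold higher number from compound 1 to compound 4 (0.15 log units; within the scatter). Compound 4 is accordingly estimated at 40 nM in this assay, with a range from 10 nM to 160 nM.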

Compound 4, half-maximal inhibitory concentration: 18.6 nM
Compound 4: middle estimate off by 2.2-fold (0.33 log units), on the high side; low and high end bracket the measured number.
By their numbers in this assay, from the lowest: compounds 3, 4 and 1 (each within the scatter of the next, the first and the last beyond it); then compound 2.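

Replacing the amide hydrogen with isobutyl gives a 1.5-fold lower number from compound 1 to compound 4 (0.19 log units; within the scatter) in this assay and so leaves the number effectively unchanged. Among these compounds, this is the first single-place comparison in the set, and it shows that this amide nitrogen can carry a branched chain of 4 carbon atoms without a measurable loss of inhibition. No available evidence explains this lack of change.

The compounds shown carry only hydrogen or isobutyl on this nitrogen, so it remains open whether a longer chain, a chain ending in an amine or one ending in a carboxylic acid would also leave the number unchanged. As far as these compounds go, it also remains open whether the same change would give a similar result on a different core, since this is a single step from compound 1.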